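The source may hold more compounds than are shown below. What is called first, only, known or untested is meant among the compounds shown, and "the series" means these compounds.

Values in a functional assay for inhibition, with Homo sapiens as the target; a lower number here means a stronger inhibitor, a higher number a weaker inhibitor:
- compound 1 `COc1ccc(C(CC2CCCCC2)Nc2nc3ccccc3o2)cc1` gives 550 nM
- compound 2 `Cc1cccc(C(CC2CCCCC2)Nc2nc3ccccc3o2)c1` gives 300 nM
- compound 3 `CNC(=O)C(CC1CCCCC1)Nc1nc2cc(C)ccc2o1` gives 72 nM

Compound 3, at 72 nM, has the lowest number of the three, and its gaps to compound 1 and compound 2 both lie beyond the scatter. The next compound, compound 4 `Cc1ccc2oc(NC(CC3CCCCC3)c3ccccn3)nc2c1`, keeps the core of compound 3 and changes one group: pyridin-2-yl in place of methylcarbamoyl on a saturated chain carbon bound to a nitrogen on an aromatic ring and a saturated chain carbon.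

Within the data shown here, no measured step covers this exchange. Among the measured compounds shown here, the only step available, a 1.8-fold lower number from compound 1 to compound 2 (0.26 log units; within the scatter), swaps one aromatic group for another and stays within the scatter, so the choice of aromatic group gives little guidance here. For the measured compounds named here, still, compound 1 and compound 2 are the only measured compounds with an aromatic ring at this place, although their core is not that of compound 4. Compound 4 is therefore expected to sit nearer to their values than to that of compound 3. The expected change is a 3.3-fold higher number from compound 3 to compound 4 (0.52 log units; beyond the scatter), towards a higher number, and it is uncertain. For compound 4 the estimated value is 240 nM, with an expected range of 70 nM to 800 nM.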

Compound 4, half-maximal inhibitory concentration: 4 nM
Compound 4: middle estimate off by 60-fold (1.78 log units), on the high side, and the stated range ends above it.
By their numbers in this assay, from the lowest: compound 4; then compound 3; then compounds 2 and 1 (each within the scatter of the next).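

The exchange of methylcarbamoyl for pyridin-2-yl on a saturated chain carbon bound to a nitrogen on an aromatic ring and a saturated chain carbon gives an 18-fold lower number from compound 3 to compound 4 (1.26 log units; beyond the scatter) in this assay and so shows that this place can carry a large change towards a stronger inhibitor. Among these compounds, the only earlier step at this place, a 1.8-fold lower number from compound 1 to compound 2 (0.26 log units; within the scatter) and thus within the scatter, exchanged one aromatic group for another and gave no sign of how far the number could move. No measured finding explains why the pyridin-2-yl compound is so much stronger, so the data record the size of the change and not its cause.

The compounds shown leave open whether the gain depends on the ring nitrogen of pyridin-2-yl or on the ring alone, and a plain phenyl or a pyridin-3-yl group on the core of compound 4 would separate these two cases. They also leave open how the 3-methylphenyl group of compound 2 and the 4-methoxyphenyl group of compound 1 would read on that same core.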